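From compound 2 to compound 3: little change expected

The source may report more compounds than this note shows. Statements on the series, on what has been measured and on what is new or still open speak of the compounds shown alone.

In an ADME assay on Vero cells (Chlorocebus sabaeus) for cytotoxicity, read by MTT assay, with a stated time of 72 h (a higher number here means that more compound is tolerated, a lower number that less compound is tolerated), compound 1 (`COc1c(N2CCN(CC#N)C(C)C2)c(F)cc2c(=O)c(C(=O)O)cn(C3CC3)c12`) gives 354 ug/mL and compound 2 (`COc1c(N2CCN(C/C(C)=N/NC(C)=O)C(C)C2)c(F)cc2c(=O)c(C(=O)O)cn(C3CC3)c12`) gives 707 ug/mL. These two values lie within the scatter of each other, so the numbers do not separate compound 2 from compound 1. Compound 3 (`COc1c(N2CCN(CC/C(C)=N/NC(N)=O)C(C)C2)c(F)cc2c(=O)c(C(=O)O)cn(C3CC3)c12`) has not yet been measured in this assay. It shares the core of compound 2 and differs only in the side group: a group of 8 heavy atoms (4 carbon, 3 nitrogen, 1 oxygen; no ring) in place of a group of 7 heavy atoms (4 carbon, 2 nitrogen, 1 oxygen; no ring), on a saturated chain carbon bound to an amine nitrogen in a ring. A single measured step bears on this change, and it falls at the same place, on a saturated chain carbon bound to an amine nitrogen in a ring. That step, a 2.0-fold higher number from compound 1 to compound 2 (0.30 log units; within the scatter), exchanges a small group for a larger one and stays within the scatter. On the strength of that one step, no shift beyond the scatter is expected, and the data give no firm direction. The estimate is a 1.2-fold lower number from compound 2 to compound 3 (0.07 log units; within the scatter), an expected step that remains within the scatter. Compound 3 is therefore expected at 600 ug/mL, with an estimated range from 280 ug/mL to 1200 ug/mL.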

Compound 3, half-maximal cytotoxic concentration: 31.3 ug/mL
For compound 3 the middle estimate is 19-fold (1.28 log units) above the measured one; measured number below the stated range.
By their numbers in this assay, from the lowest: compound 3; then compounds 1 and 2 (each within the scatter of the next).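

In this assay, among these compounds, the saturated chain carbon bound to an amine nitrogen in a ring proves sensitive to the group it carries, which the earlier pair could not show: the change to the group of 8 heavy atoms gives a 23-fold lower number from compound 2 to compound 3 (1.35 log units; beyond the scatter) and so yields the first step at this place beyond the scatter. The same group also stands clearly apart from the smaller group of compound 1, with an 11-fold lower number from compound 1 to compound 3 (1.05 log units; beyond the scatter) as the step, whereas the exchange of that smaller group for the group of 7 heavy atoms in compound 2 stayed within the scatter, so among these three compounds the number does not simply follow the size of the group. Nothing at hand accounts for the drop.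

The entering group differs from the leaving one in more than a single feature, and the compounds shown do not tell which feature goes with the lower number. As far as these compounds go, a longer chain ending in the acetyl hydrazone of compound 2, or the same chain ending in an amine or a carboxylic acid, remains open.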